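Two pyrazolopyridine amines and a piperidine variant

The source may hold more compounds than are shown below. What is called first, only, known or untested is meant among the compounds shown, and "the series" means these compounds.

Compound 1 `Nc1n[nH]c2cc(-c3ccccn3)[nH]c(=O)c12` and compound 2 `COCCNc1nc(C)cc2nn(-c3ccccc3)c(N)c12` were both examined in an assay on isolated protein for inhibition of RAC-alpha serine/threonine-protein kinase (Homo sapiens), read by mobility shift assay, tested at 30 uM; a lower number here means less inhibition, a higher number more inhibition at the concentration tested (going by the name of the read-out). In this assay compound 1 gives 2%, and compound 2 gives 3%. Among the measured compounds shown here, the two numbers lie within the scatter of each other, so neither compound can be set apart from the other; both show little inhibition at the concentration tested, and no step between them can be described beyond what the two values themselves show.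

Compound 3 `Cc1cc2nn(-c3ccccc3)c(N)c2c(N2CCCCC2)n1` has not yet been measured in this assay. It differs from compound 2 in one place: piperidin-1-yl in place of (2-methoxyethyl)amino on an aromatic carbon. The change sits on an aromatic carbon of the six-membered aromatic ring with one nitrogen in the fused system, next to the ring nitrogen.

For the measured compounds named here, with only two measured compounds, both near the floor of the read-out, no step has been observed on which to build a trend. The expectation for the step of a number 2 percentage points higher from compound 2 to compound 3 (within the scatter) is therefore none beyond the scatter. For compound 3 the estimate in this assay is 5%, with a range from -8% to 20%.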

Compound 3, a percentage reported as inhibition, at one concentration (the size of the read-out at that concentration, not a potency): 1%
Estimate against measurement, compound 3: 4 percentage points above, and the stated range covers the measured number.
By their numbers in this assay, from the lowest: compounds 3, 1 and 2 (each within the scatter of the next).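

Placing piperidin-1-yl instead of (2-methoxyethyl)amino on the aromatic carbon next to the ring nitrogen gives, in this assay, a number 2 percentage points lower from compound 2 to compound 3 (within the scatter). Among the compounds shown here, this is the first step that can be read at this position, and it shows that the open chain, with its hydrogen-bond donor and its oxygen, can give way to a six-membered non-aromatic ring without any difference that the read-out can separate from scatter; compound 2 stays at 3% and compound 3 stands at 1%, so both remain close to the bottom of the read-out and the change neither adds to nor clearly takes from the little inhibition seen. Nothing is available that bears on why the two groups read alike.

With both values this low, the step says little about how much this position can matter, since a group that raised inhibition well beyond the scatter has yet to appear among these compounds. As far as these compounds go, whether a morpholin-4-yl group, a primary amine or a longer chain ending in a carboxylic acid on this same carbon would lift the number remains open.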